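The compounds below may be only part of what the source reports. "The series", "measured", "known", "first", "only" and "open" are said of these compounds alone.

In a functional assay on B16-F10 cells (Mus musculus) for antiproliferative activity, read by MTT assay, with a stated time of 48 h (on this read-out higher numbers stand for weaker inhibition and lower numbers for stronger inhibition), three compounds have been measured so far:

- compound 1 `COc1ccc(/C=C/C(=O)Nc2cc(-c3ccc(Br)cc3)[nH]n2)cc1` gives 770 nM
- compound 2 `O=C(/C=C/c1ccc(Cl)cc1)Nc1cc(-c2ccccc2)[nH]n1` gives 1270 nM
- compound 3 `O=C(/C=C/c1ccc(Br)cc1)Nc1cc(-c2ccc(Br)cc2)[nH]n1` gives 1280 nM

All three numbers lie within the usual scatter of one another, so compound 3 stands level with the other two and cannot be separated from them.

The next compound, compound 4 `O=C(/C=C/c1ccc(Br)cc1)Nc1cc(-c2ccccc2)[nH]n1`, comes from compound 3 by a single change, hydrogen in place of bromo on an aromatic carbon, so that 4-bromophenyl becomes phenyl.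

Only one measured step links two of these compounds by a single change: a 1.7-fold higher number from compound 1 to compound 3 (0.22 log units; within the scatter). That step is small, but it concerns the methoxy group of compound 1 and not the bromo that leaves here, so it bears only indirectly. Compound 2 already carries the phenyl that compound 4 will have, and compound 2 gives 1270 nM, level with compound 3. Going by the values given here, nothing measured so far points to a large effect from this swap, so no change beyond the scatter is expected in this assay.

The expected step is a 1.1-fold lower number from compound 3 to compound 4 (0.03 log units; within the scatter), which is only an estimate. For compound 4 the estimated value is 1200 nM, with an expected range from 600 nM to 2400 nM.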

Compound 4, half-maximal inhibitory concentration: 1380 nM
Compound 4: the middle estimate sits 1.2-fold (0.06 log units) below what was measured; low and high end bracket the measured number.
By their numbers in this assay, from the lowest: compounds 1, 2, 3 and 4 (each within the scatter of the next).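

In this assay, the change of 4-bromophenyl to phenyl gives a 1.1-fold higher number from compound 3 to compound 4 (0.03 log units; within the scatter). For a newcomer, this is the useful point: at this position, on a six-membered aromatic ring of carbon only and para to a large group, bromo and hydrogen cannot be told apart in this test, and at another place in the molecule, bromo in place of chloro on an aromatic carbon gives a 1.1-fold higher number from compound 2 to compound 4 (0.04 log units; within the scatter), so neither of these two single swaps moves the number beyond what repeated measurements would show. Nothing further is at hand that could bear on these results.

Bromo and hydrogen are only two possible occupants of this position, so it remains open whether an amine, a carboxylic acid, a methoxy group or a longer chain placed there would leave the number level or shift it clearly. Going by these compounds, it also remains open whether bromo and hydrogen would still stand level at this position in a compound carrying the methoxy group of compound 1 in place of the other halogen.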